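Substituent exchange on the five-membered ring: compound 3

A few compounds are considered here, and "the series" means these few. Any claim that something is new, unique, unknown or untested is made for them only; others in the source may bear on it.

Compound 2 `C[C@@H]1CN(c2sc(C3COC3)nc2-c2nc3ccccc3[nH]2)CCN1C(=O)Cn1cnc2cccnc21` carries the oxetan-3-yl group on the five-membered aromatic ring with 1 nitrogen and 1 sulfur. Within the data shown here, in a functional assay on U2OS cells for antagonist activity at C-X-C chemokine receptor type 3 (Homo sapiens), read by beta-arrestin recruitment (on this read-out lower numbers stand for stronger inhibition and higher numbers for weaker inhibition), compound 2 gives 6220 nM, the only number in the set so far. Compound 1 `C[C@@H]1CN(c2sc(CO)nc2-c2nc3ccccc3[nH]2)CCN1C(=O)Cn1cnc2cccnc21` carries hydroxymethyl at the same place; in this assay compound 1 reaches only > 10000 nM, which is a limit of the assay and not a number (the limit of > 10000 nM in this assay, at which 1 of the 2 values shown sits). Among the measured compounds shown here, the single measured step, an at least 1.6-fold lower number from compound 1 to compound 2 (0.20 log units; that floor lies within the scatter), therefore shows only that the oxetan-3-yl compound falls inside the measurable range.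

Compound 3 `C[C@@H]1CN(c2sc(C(F)(F)F)nc2-c2nc3ccccc3[nH]2)CCN1C(=O)Cn1cnc2cccnc21` carries the change (trifluoromethyl in place of oxetan-3-yl on an aromatic carbon). For the measured compounds named here, no measured step involves a trifluoromethyl group, and the one step on record compares hydroxymethyl with oxetan-3-yl, so it bears on the new step only in showing that this position tolerates exchange while the numbers stay weak. The step expected in this assay is a 1.4-fold lower number from compound 2 to compound 3 (0.14 log units; within the scatter), with no direction asserted beyond the scatter. The estimate for compound 3 in this assay is 4500 nM, expected to lie between 1500 nM and 15000 nM, with a real chance that only a limit is returned.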

Compound 3, half-maximal inhibitory concentration: 31 nM
Beside the measured number, compound 3's estimate is 150-fold (2.16 log units) above it; measured number below the stated range.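

This position, on an aromatic carbon next to the ring nitrogen and next to the ring sulfur, does more than tolerate exchange: in this assay, trifluoromethyl in place of oxetan-3-yl gives a 200-fold lower number from compound 2 to compound 3 (2.30 log units; beyond the scatter), although both groups have 4 heavy atoms. Trifluoromethyl in place of hydroxymethyl gives an at least 320-fold lower number from compound 1 to compound 3 (2.50 log units; beyond the scatter), so the substituent here can move the series well out of the weak range, which the earlier step, a floor within the scatter, could not show. The value of compound 1 remains a limit of the assay and not a number, so this second step is a floor as well: the limit of > 10000 nM in this assay, at which 1 of the 3 values shown sits.

The compounds shown do not separate which feature of trifluoromethyl goes with the step, since the entering group differs from oxetan-3-yl in having no ring and no hydrogen-bond acceptor, and no measured property of either group stands beside the values. From the compounds shown here alone, whether methyl, chlorine, a nitrile or a longer chain such as pentafluoroethyl at this position would match compound 3 at 31 nM stays open.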